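This account rests on a few compounds, and the source may have more. Where it says the series, first, only, none or still open, it means among the compounds named here.

Measured compounds:
- compound 1 `O=C(c1ccc(F)cc1)N1CCCn2nc(COc3ccccc3)cc21`: 63%
- compound 2 `CC(=O)N1c2cc(COc3ccccc3)nn2CCC1C`: 67%

The account follows one step. In a functional assay on HEK293 cells for positive allosteric modulation of metabotropic glutamate receptor 5 (Homo sapiens), read by calcium flux (on this read-out higher numbers stand for larger maximal responses and lower numbers for smaller maximal responses), compound 1 gives 63%, and in this assay compound 2 gives 67%. Among the compounds with values here, the two numbers lie within the usual scatter of each other, so compound 2 cannot be set apart from compound 1 on these data; no step between two measured compounds is known.

Compound 3 `CC(=O)N1c2cc(COc3ccccc3)nn2CCC1c1ccccc1` shares the core of compound 2 and differs from it in one place: phenyl in place of methyl on a saturated ring carbon. Within the data shown here, there is no measured step of this kind to lean on, so the expected change in this assay is none beyond the scatter, in either direction. The step from compound 2 to compound 3 is expected to be a number 2 percentage points lower from compound 2 to compound 3 (within the scatter). On that basis compound 3 is estimated to give 65% in this assay, with a range from 45% to 85%.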

Compound 3, largest response reached (reported as percent of maximum), in percent of the reference or control that the assay uses: 38%
Compound 3: the middle estimate sits 27 percentage points above what was measured; the measured number lies below the stated range.
By their numbers in this assay, from the lowest: compound 3; then compounds 1 and 2 (each within the scatter of the next).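

In this assay, within the data shown here, the methyl on this saturated ring carbon cannot be exchanged for phenyl without cost: the change gives a number 29 percentage points lower from compound 2 to compound 3 (beyond the scatter) and is the first step here that lies beyond the scatter. This shows that the maximal response depends on the group at this position, which compounds 1 and 2 alone could not show. Nothing available here accounts for this loss.

As far as these compounds go, it remains open whether a smaller group such as ethyl or cyclopropyl would keep the response of compound 2, or whether a pyridyl ring would behave as phenyl does. From the compounds shown here alone, it is also open whether phenyl at this carbon would cost as much with the 4-fluorobenzoyl group of compound 1 in place of the acetyl group.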